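The source may hold more compounds than are shown below. What is called first, only, known or untested is meant among the compounds shown, and "the series" means these compounds.

In an ADME assay on H9 cells (Homo sapiens) for cytotoxicity, read by XTT assay, with a stated time of 6 days (on this read-out lower numbers stand for higher toxicity in this test and higher numbers for lower toxicity in this test), three compounds sharing one core have been measured: compound 1 `Cc1cc(Br)cc(C)c1Oc1cc(Nc2ccc(C#N)cc2)c(N)cc1N` gives 38400 nM, compound 2 `Cc1cc(C#N)cc(C)c1Oc1cc(Nc2ccc(C#N)cc2)c(N)cc1N` gives 51000 nM, and compound 3 `Cc1cc(C)c(Oc2cc(Nc3ccc(C#N)cc3)c(N)cc2N)c(C)c1` gives 50000 nM. Compound 3 thus cannot be told apart from either of the others. Compound 4 `Cc1cccc(C)c1Oc1cc(Nc2ccc(C#N)cc2)c(N)cc1N` carries one change from compound 3: hydrogen in place of methyl on an aromatic carbon. The measured swaps at that same place are small: a 1.3-fold higher number from compound 1 to compound 3 (0.11 log units; within the scatter), a 1.3-fold higher number from compound 1 to compound 2 (0.12 log units; within the scatter) and a 1.0-fold lower number from compound 2 to compound 3 (0.01 log units; within the scatter). None involves hydrogen, so the evidence is indirect, but no step beyond the scatter is expected. The estimated change is a 1.0-fold lower number from compound 3 to compound 4 (0.02 log units; within the scatter). The expected value for compound 4 is 48000 nM, with an estimated range of 25000 nM to 90000 nM.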

Compound 4, half-maximal cytotoxic concentration: 53200 nM
Compound 4: the middle estimate sits 1.1-fold (0.04 log units) below what was measured, and the stated range covers the measured number.
By their numbers in this assay, from the lowest: compounds 1, 3, 2 and 4 (each within the scatter of the next).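

Hydrogen now joins methyl, cyano and bromo at the ring position para to a large group, and the steps of a 1.1-fold higher number from compound 3 to compound 4 (0.03 log units; within the scatter) and a 1.0-fold higher number from compound 2 to compound 4 (0.02 log units; within the scatter) and a 1.4-fold higher number from compound 1 to compound 4 (0.14 log units; within the scatter) all lie within the scatter in this assay. So even with no group at all at this position, the number does not move beyond the scatter, which the earlier swaps between groups could not show. No measured evidence speaks to the reason for this.

From the compounds shown here alone, whether an amine or a carboxylic acid at this position would give a step beyond the scatter remains open. So does the effect of changing the two methyl groups on the same ring.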